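Swapping cyclopentyl for an aryl amine on the shared core

The compounds below may be only part of what the source reports. "The series", "measured", "known", "first", "only" and "open" are said of these compounds alone.

Compound 1 `O=C1C(NC2CCCC2)=CC(=O)c2c1nc1n2[C@H]2OC[C@@H](O)[C@H]2OC1` sits at the weak end of what has been measured: in a functional assay on HeLa cells (Homo sapiens) for inhibition, read by sulforhodamine B assay (on this read-out higher numbers stand for weaker inhibition and lower numbers for stronger inhibition), compound 1 reaches only the limit of > 16000 nM, so no number is known for it, and that limit is where it stands (the limit of > 16000 nM in this assay, at which 1 of the 3 values shown sits). Compound 4 `CCOc1ccccc1NC1=CC(=O)c2c(nc3n2[C@H]2OC[C@@H](O)[C@H]2OC3)C1=O` keeps the core of compound 1 and changes only the group on the amine nitrogen (2-ethoxyphenyl in place of cyclopentyl on an amine nitrogen).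

Going by the values given here, no measured step covers this exact change. The nearest evidence comes from compound 2 `CCOc1ccccc1NC1=CC(=O)c2nc3n(c2C1=O)[C@H]1OC[C@@H](O)[C@H]1OC3`, which carries the same 2-ethoxyphenyl group on an amine nitrogen and gives 6040 nM in this assay, and from compound 3 `O=C1C=C(Nc2ccccc2)C(=O)c2c1nc1n2[C@H]2OC[C@@H](O)[C@H]2OC1`, which gives 5620 nM. The step of a 1.1-fold lower number from compound 2 to compound 3 (0.03 log units; within the scatter) shows that removing the ethoxy changes little. Both aryl amines therefore sit at a measurable number, whereas compound 1 gives only a limit.

On that basis compound 4 is expected to show a step of an at least 2.6-fold lower number from compound 1 to compound 4 (0.42 log units; beyond the scatter) toward stronger inhibition. The estimate for compound 4 is 6000 nM, with a range of 2500 nM to 16000 nM.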

Compound 4, half-maximal inhibitory concentration: 8300 nM
The estimate for compound 4 lay 1.4-fold (0.14 log units) below the measured number, within the range that was stated.
By their numbers in this assay, from the lowest: compounds 3, 2 and 4 (each within the scatter of the next). At a limit, above all of these: compound 1.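

Going by these compounds alone, on the shared core, this is the first direct pair for a change on the amine nitrogen: in this assay, 2-ethoxyphenyl in place of cyclopentyl gives an at least 1.9-fold lower number from compound 1 to compound 4 (0.28 log units; that floor lies within the scatter). With the aryl group compound 4 reaches a number, whereas the cyclopentyl group of compound 1 leaves only a limit of the assay. The true size of the step cannot be read, and even a real gain is unproven, because the floor rests on that limit: the limit of > 16000 nM in this assay, at which 1 of the 4 values shown sits.

The compounds shown leave open how a simple alkyl chain such as butyl, a benzyl group or a saturated ring carrying an oxygen, such as tetrahydropyranyl, would read on this nitrogen. They also leave open whether a group other than ethoxy on the phenyl ring, such as a carboxylic acid or a dimethylamino group, would shift the number.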